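Dimethylamino for methoxy: cytotoxicity notes on the series

The compounds below may be only part of what the source reports. "The series", "measured", "known", "first", "only" and "open" are said of these compounds alone.

Measured in an ADME assay on LLC-MK2 cells (Macaca mulatta) for cytotoxicity, read by MTT assay, with a stated time of 48 h; on this read-out higher numbers stand for lower toxicity in this test and lower numbers for higher toxicity in this test:
- compound 1 `C/C(=C\c1ccc([N+](=O)[O-])cc1)C(=O)/C=C/c1ccc(N(C)C)cc1`: 25900 nM
- compound 2 `COc1ccc(/C=C/C(=O)/C(C)=C/c2ccc(N(C)C)cc2)cc1`: 285000 nM

Of these two measured compounds, compound 2 holds the higher number at 285000 nM. The gap down to compound 1 at 25900 nM lies beyond the scatter. The two differ in more than one place, so that gap cannot be tied to any single change.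

The next compound is compound 3 `C/C(=C\c1ccc(N(C)C)cc1)C(=O)/C=C/c1ccc(N(C)C)cc1`, which keeps the rest of compound 2 and carries dimethylamino in place of methoxy on an aromatic carbon, para to a large group (dimethylamino in place of methoxy on an aromatic carbon).

Among the measured compounds shown here, no measured pair shows this exchange, so the expectation is only loosely anchored. In this assay, compound 1 at 25900 nM shows that the series can reach clearly lower numbers, and compound 2 already stands at the top of what has been seen. The expected move is therefore downward and modest, and a result within the scatter would not be surprising. The estimated step is a 2.6-fold lower number from compound 2 to compound 3 (0.41 log units; beyond the scatter). For compound 3 the estimated value is 110000 nM, with an expected range of 35000 nM to 320000 nM.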

Compound 3, half-maximal cytotoxic concentration: 314000 nM
The estimate for compound 3 lay 2.9-fold (0.46 log units) below the measured number; low and high end bracket the measured number.
By their numbers in this assay, from the lowest: compound 1; then compounds 2 and 3 (each within the scatter of the next).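

In this assay, dimethylamino in place of methoxy on this aromatic carbon, para to a large group, gives a 1.1-fold higher number from compound 2 to compound 3 (0.04 log units; within the scatter), so this exchange does not separate the two groups in this test. Among the compounds shown here, the same position also gives the first single-place reading of the earlier gap: dimethylamino in place of nitro gives a 12-fold higher number from compound 1 to compound 3 (1.08 log units; beyond the scatter), which ties a large step to this one position and leaves the nitro-bearing compound 1 alone at the low end of the numbers, the end of higher toxicity in this test. Nothing available bears on why nitro stands apart from methoxy and dimethylamino here.

Going by these compounds, whether the lower number belongs to nitro alone, or also appears with another group at this position such as chloro, trifluoromethyl or a carboxylic acid, remains open. Also open, on these data alone, is whether the same picture holds when the dimethylamino group shared by all three compounds on the other side of the core gives way to another group, such as a primary amine.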